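The source may report more compounds than this note shows. Statements on the series, on what has been measured and on what is new or still open speak of the compounds shown alone.

Two compounds built on the same core, each carrying a nitrile-bearing side chain, have been measured in a functional assay on THP-1 cells (Homo sapiens) for inhibition, read by sulforhodamine B assay, with a stated time of 48 h; a higher number here means a weaker inhibitor of growth, a lower number a stronger inhibitor of growth. Compound 1 `N#CCC1=C(C#N)CC(c2ccc([N+](=O)[O-])cc2)=C(CC(=O)c2ccc(Br)cc2)O1` gives 26000 nM in this assay. Compound 2 `N#CCC1=NN=C(c2ccc(Br)cc2)C(CC(=O)c2ccc([N+](=O)[O-])cc2)O1` gives 20000 nM in this assay. Of the two numbers, compound 2 holds the lower one, but the gap to compound 1 lies inside the usual scatter of such measurements, so on these figures the two cannot be told apart.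

Compound 3 `N#CCC1=NN=C(c2ccc([N+](=O)[O-])cc2)C(CC(=O)c2ccc([N+](=O)[O-])cc2)O1` has not yet been measured. It differs from compound 2 in a single place: nitro in place of bromo on an aromatic carbon. Within the data shown here, no pair of measured compounds differs in exactly this way, so there is no measured step to lean on. What the two measured compounds do show is that a nitro group and a bromo group, each present once and in swapped arrangement, give numbers that sit together within the scatter. On that basis the expected step is no change at the digits printed from compound 2 to compound 3 (within the scatter), which is to say nothing beyond the scatter. Compound 3 is therefore expected near 20000 nM, in a range from 8000 nM to 50000 nM.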

Compound 3, concentration for 50% growth inhibition: 33000 nM
For compound 3 the middle estimate is 1.7-fold (0.22 log units) below the measured one; the measured number falls inside the stated range.
By their numbers in this assay, from the lowest: compounds 2, 1 and 3 (each within the scatter of the next).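

In this assay, replacing 4-bromophenyl with 4-nitrophenyl gives a 1.7-fold higher number from compound 2 to compound 3 (0.22 log units; within the scatter), so compound 2 and compound 3 cannot be told apart. This is the first direct reading of a single change among these compounds: at this aromatic carbon, para to a large group, a lone bromine gives way to a nitro group with its three heavy atoms and two hydrogen-bond acceptors, and growth inhibition shows no difference beyond the scatter. The earlier pair offered no such one-place comparison, whereas this step ties the two groups together directly at this position, though no measurement is available here to account for the result.

As far as these compounds go, with only bromo and nitro compared at this position, it remains open whether an amine, a carboxylic acid or a methoxy group there would give a number beyond the scatter of those of compound 2 and compound 3. Also open, from the compounds shown here alone, is whether the same exchange on the other aromatic ring, which would put bromo on the ring carrying the carbonyl-bearing side chain, would give a similarly small step.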